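The source may report more compounds than this note shows. Statements on the series, on what has been measured and on what is new or still open speak of the compounds shown alone.

Compound 3 `CCCSc1nc(N/N=C/c2ccc3ccccc3c2)c2nnn(Cc3ccccc3)c2n1` stands at a limit in a functional assay on MGC-803 cells (Homo sapiens) for antiproliferative activity, read by MTT assay, with a stated time of 72 h (on this read-out higher numbers stand for weaker inhibition and lower numbers for stronger inhibition), returning > 64000 nM rather than a number. Compound 1 `CCCSc1nc(N/N=C/c2ccc(Cl)cc2)c2nnn(Cc3ccccc3)c2n1` likewise gives only a limit in this assay, > 64000 nM. Compound 2 `CCCSc1nc(N/N=C/c2ccc([N+](=O)[O-])cc2)c2nnn(Cc3ccccc3)c2n1` gives 10100 nM in this assay, a readable number. Among the compounds with values here, compound 2 is thus the one compound whose value is not a limit (the limit of > 64000 nM in this assay, at which 2 of the 3 values shown sit). The readable steps are an at least 6.3-fold lower number from compound 1 to compound 2 (0.80 log units; beyond the scatter) and an at least 6.3-fold higher number from compound 2 to compound 3 (0.80 log units; beyond the scatter), while a step that the two limits leave unreadable from compound 1 to compound 3 cannot be sized.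

Compound 4 `CCCSc1nc(N/N=C/c2ccccc2)c2nnn(Cc3ccccc3)c2n1` differs from compound 3 by phenyl in place of naphthalen-2-yl on a carbon with a double bond to nitrogen. Within the data shown here, the steps that bear on this position are an at least 6.3-fold higher number from compound 2 to compound 3 (0.80 log units; beyond the scatter) and a step that the two limits leave unreadable from compound 1 to compound 3; both change the group on the carbon with a double bond to nitrogen, and both end at the limit where compound 3 stands. Among the measured compounds shown here, neither involves a plain phenyl, so no measured step sets the direction. With two of three values at the limit, compound 4 is expected to stay near it, with a number no higher from compound 3 to compound 4 (the limit leaves the size open) giving the expected step. The estimate for compound 4 in this assay is 64000 nM, from 25000 nM to 200000 nM.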

Compound 4, half-maximal inhibitory concentration: > 64000 nM
Compound 4: only a limit was reported; the forecaster's own chance of this, stated with the estimate: 65%; the middle value lies on the limit itself.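

Hydrogen in place of nitro on an aromatic carbon gives an at least 6.3-fold higher number from compound 2 to compound 4 (0.80 log units; beyond the scatter), so the readable number of compound 2 is tied to its nitro group and is not shared by the plain phenyl. In this assay compound 4 gives > 64000 nM, which is a limit, so going from naphthalen-2-yl to phenyl does not bring a readable number, and the steps from compound 3 to compound 4 and from compound 1 to compound 4 cannot be read. Compound 2 alone stands off the limit: the limit of > 64000 nM in this assay, at which 3 of the 4 values shown sit.

On these data alone, how far compound 1, compound 3 and compound 4 lie beyond that limit stays open. Also open, as far as these compounds go, is whether an amine or a nitrile in place of the nitro would give a readable number as well.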